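A few compounds are considered here, and "the series" means these few. Any claim that something is new, unique, unknown or untested is made for them only; others in the source may bear on it.

Compound 1 `O=C(NCc1ccc(S(=O)(=O)c2ccccc2)cc1)c1cc2cnccc2[nH]1` and compound 2 `O=S(=O)(c1ccccc1)c1ccc(CNS(=O)(=O)N2Cc3ccncc3C2)cc1` share a benzenesulfonyl-bearing side chain. In a physicochemical assay for solubility, in phosphate buffer, with a stated time of 24 h, at pH 7.4, tested at 100 uM (on this read-out higher numbers stand for higher solubility and lower numbers for lower solubility), compound 1 gives 3000 nM, and compound 2 gives 3000 nM. Compound 3 `O=C(NCc1ccc(S(=O)(=O)C2CCC(F)(F)CC2)cc1)N1Cc2ccncc2C1` stands apart: in this assay compound 3 gives 35000 nM, the highest of the three numbers, and its gaps to both compound 1 and compound 2 lie beyond the scatter. Compound 4 `CN1CCN(S(=O)(=O)c2ccc(CNC(=O)N3Cc4ccncc4C3)cc2)CC1` is built from compound 3 by one exchange on a sulfonyl sulfur, (4-methylpiperazin-1-yl in place of 4,4-difluorocyclohexyl on a sulfonyl sulfur). Among the compounds with values here, no measured pair carries this exchange, so the expectation rests on where compound 3 sits. An upward step beyond the scatter is expected, a 2.3-fold higher number from compound 3 to compound 4 (0.36 log units; beyond the scatter). Compound 4 is therefore estimated at 80000 nM, with a range from 40000 nM to 100000 nM.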

Compound 4, solubility: 160000 nM
Beside the measured number, compound 4's estimate is 2.0-fold (0.30 log units) below it, and the stated range ends below it.
By their numbers in this assay, from the lowest: compounds 1 and 2 (each within the scatter of the next); then compound 3; then compound 4.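

Within the data shown here, at the sulfonyl sulfur whose other neighbour is an aromatic carbon, the exchange gives the first step that can be read in this assay, a 4.6-fold higher number from compound 3 to compound 4 (0.66 log units; beyond the scatter). This shows that the read-out responds to the group at this position, and that the number rises when 4-methylpiperazin-1-yl, a ring with 2 hetero atoms, replaces a ring of carbon only. Nothing available explains the size or direction of this step.

Going by these compounds, it remains open whether the ring nitrogens, the methyl group or the absence of fluorine accounts for the step. The compounds shown do not tell how a piperidin-1-yl, morpholin-4-yl or unmethylated piperazin-1-yl group would read at this sulfur.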